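A few compounds are considered here, and "the series" means these few. Any claim that something is new, unique, unknown or untested is made for them only; others in the source may bear on it.

Compound 1 `CCN1CCN(c2cc(C)c3cc(NC(=O)c4cccc(Cl)c4)ccc3n2)CC1` — 3820 nM
Compound 2 `Cc1cc(NCCN(C)C)nc2ccc(NC(=O)c3ccc(Cl)c(Cl)c3)cc12` — 2550 nM
Compound 3 `Cc1cc(NCCN2CCN(C)CC2)nc2ccc(NC(=O)c3ccc(Cl)c(Cl)c3)cc12` — 1700 nM

All three were tested in a functional assay on MCF7 cells (Homo sapiens) for antiproliferative activity, read by MTT assay, with a stated time of 72 h; a higher number here means a weaker inhibitor, a lower number a stronger inhibitor. Compound 1 has the highest number of the three; compound 2 lies within the scatter of it, while compound 3 is lower by a margin beyond the scatter. For the measured compounds named here, the only measured step, a 1.5-fold lower number from compound 2 to compound 3 (0.18 log units; within the scatter), concerns a different part of the molecule and stays within the scatter. Compound 4 `CCN1CCN(c2cc(C)c3cc(NC(=O)c4ccc5ccccc5n4)ccc3n2)CC1` differs from compound 1 by quinolin-2-yl in place of 3-chlorophenyl on a carbonyl carbon. Going by the values given here, no measured step touches the group on the carbonyl carbon, so the data offer no footing for a shift beyond the scatter in this assay in either direction. Compound 4 is therefore expected to give about 3000 nM, between 1000 nM and 9000 nM. For compound 4 this estimate means a step of a 1.3-fold lower number from compound 1 to compound 4 (0.10 log units; within the scatter).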

Compound 4, half-maximal inhibitory concentration: 7060 nM
Beside the measured number, compound 4's estimate is 2.4-fold (0.37 log units) below it; low and high end bracket the measured number.
By their numbers in this assay, from the lowest: compounds 3, 2, 1 and 4 (each within the scatter of the next, the first and the last beyond it).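

In this assay, for the compounds shown here, the group on the carbonyl carbon is changed for the first time, and quinolin-2-yl in place of 3-chlorophenyl gives a 1.8-fold higher number from compound 1 to compound 4 (0.27 log units; within the scatter) and so no shift beyond the scatter. This position therefore accepts the added six-membered aromatic ring and its hydrogen-bond acceptor without a clear change in this assay. Nothing on hand explains this result.

The compounds shown leave open how pyridin-2-yl or naphthalen-2-yl would behave on this carbonyl carbon, which would separate the ring nitrogen from the second ring.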